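The compounds below may be only part of what the source reports. "The series", "measured", "known", "first", "only" and "open" are said of these compounds alone.

Within the data shown here, in a functional assay on HepG2 cells (Homo sapiens) for antiproliferative activity, read by CCK-8 assay, with a stated time of 48 h (a lower number here means a stronger inhibitor, a higher number a weaker inhibitor), compound 1 (`COc1ccc(/C=C\c2cc(OC)c(OC)c(OC)c2)cc1OCc1ccc(C=O)cc1`) gives 800 nM and compound 2 (`COc1ccc(/C=C\c2cc(OC)c(OC)c(OC)c2)cc1OCc1ccc(CN2CCCCC2C(=O)O)cc1`) gives 3100 nM, the higher of the two numbers so far. Compound 3 (`COc1ccc(/C=C\c2cc(OC)c(OC)c(OC)c2)cc1OCc1ccc(CNCCO)cc1`) differs from compound 2 in one place: (2-hydroxyethyl)amino in place of 2-carboxypiperidin-1-yl on a saturated chain carbon bound to an aromatic carbon. Among the measured compounds shown here, the one measured step that bears on this, a 3.9-fold higher number from compound 1 to compound 2 (0.59 log units; beyond the scatter), is modest and put (2-carboxypiperidin-1-yl)methyl in place of formyl. For the measured compounds named here, no measured compound carries (2-hydroxyethyl)amino, so that step gives only a rough guide to size. A modest move toward a lower number in this assay is expected, shown as a 2.2-fold lower number from compound 2 to compound 3 (0.35 log units; beyond the scatter). The estimate for compound 3 is 1400 nM, with an expected range of 400 nM to 4500 nM.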

Compound 3, half-maximal inhibitory concentration: 5900 nM
Beside the measured number, compound 3's estimate is 4.2-fold (0.62 log units) below it; the whole stated range lies below it.
By their numbers in this assay, from the lowest: compound 1; then compounds 2 and 3 (each within the scatter of the next).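

In this assay, (2-hydroxyethyl)amino in place of 2-carboxypiperidin-1-yl gives a 1.9-fold higher number from compound 2 to compound 3 (0.28 log units; within the scatter), so the ring and the larger group are not needed to reach this level, and the two groups cannot be told apart here. Replacing formyl with ((2-hydroxyethyl)amino)methyl gives a 7.4-fold higher number from compound 1 to compound 3 (0.87 log units; beyond the scatter), making this the second replacement of formyl on an aromatic carbon to end on the higher side. No evidence on hand explains either step. Still open, as far as these compounds go, is whether a morpholine or a plain dimethylamino group on a saturated chain carbon bound to an aromatic carbon would differ from these two groups.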